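Longer ester chains on a quinazoline core: cytotoxicity

The compounds below may be only part of what the source reports. "The series", "measured", "known", "first", "only" and "open" are said of these compounds alone.

Measured compounds:
compound 1 `CCCCCCCCCCCOC(=O)CCC(=O)N1CCN(CCCOc2cc3c(Nc4ccc(F)c(Cl)c4)ncnc3cc2OC)CC1` gives 2.8%
compound 2 `CCCCCCCCCCCCOC(=O)CCC(=O)N1CCN(CCCOc2cc3c(Nc4ccc(F)c(Cl)c4)ncnc3cc2OC)CC1` gives 2.3%
compound 3 `CCCCCCCCCCCCCOC(=O)CCC(=O)N1CCN(CCCOc2cc3c(Nc4ccc(F)c(Cl)c4)ncnc3cc2OC)CC1` gives 6.8%

In a functional assay on A549 cells (Homo sapiens) for cytotoxicity, read by MTT assay, with a stated time of 24 h, tested at 80 uM (on this read-out lower numbers stand for a stronger effect and higher numbers for a weaker effect at the one concentration tested), all three compounds share one core and differ only in the length of the saturated chain on the ester. Compound 3 sits at 6.8%; its steps from the others, a number 4 percentage points higher from compound 1 to compound 3 (within the scatter) and a number 4.5 percentage points higher from compound 2 to compound 3 (within the scatter), both lie within the scatter, as does a number 0.5 percentage points lower from compound 1 to compound 2 (within the scatter). Compound 4 `CCCCCCCCCCCCCCCOC(=O)CCC(=O)N1CCN(CCCOc2cc3c(Nc4ccc(F)c(Cl)c4)ncnc3cc2OC)CC1` continues the series: ethyl in place of hydrogen on a saturated chain carbon, ten or more bonds along the chain from an oxygen next to a carbonyl group. Every earlier lengthening of this chain moved the read-out by less than the scatter, so no step beyond the scatter is expected here either. Compound 4 is therefore estimated at 5%, between 0% and 14%, an expected step of a number 1.8 percentage points lower from compound 3 to compound 4 (within the scatter).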

Compound 4, a percentage reported as activity, at one concentration (the size of the read-out at that concentration, not a potency): 81.1%
For compound 4 the middle estimate is 76.1 percentage points below the measured one, outside the stated range (above it).
By their numbers in this assay, from the lowest: compounds 2, 1 and 3 (each within the scatter of the next); then compound 4.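

In this assay, for the compounds shown here, this chain position proves far less tolerant than the earlier compounds suggested. Adding ethyl gives a sharp loss of effect (a number 74.3 percentage points higher from compound 3 to compound 4 (beyond the scatter)), and the comparisons with the shorter chains agree (a number 78.8 percentage points higher from compound 2 to compound 4 (beyond the scatter); a number 78.3 percentage points higher from compound 1 to compound 4 (beyond the scatter)), so lengthening can switch the effect off abruptly rather than gradually. Nothing available here explains this sudden change.

On these data alone, whether a longer chain would keep the effect lost remains open, as does what a carboxylic acid or an amine in place of this chain would do.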